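Amide aryl change on the shared core, compound 2 to 3

The source may hold more compounds than are shown below. What is called first, only, known or untested is meant among the compounds shown, and "the series" means these compounds.

Values from a functional assay on K562 cells (Homo sapiens) for inhibition, read by MTT assay, with a stated time of 48 h (on this read-out lower numbers stand for stronger inhibition and higher numbers for weaker inhibition), so far:
- compound 1 `Nc1n[nH]c2cc(-c3cn([C@@H]4CN[C@H](C(=O)Nc5ccc(Cl)c(C(F)(F)F)c5)C4)nn3)ccc12` gives 8320 nM
- compound 2 `Nc1n[nH]c2cc(-c3cn([C@@H]4CN[C@H](C(=O)Nc5ccc(Cl)cc5Cl)C4)nn3)ccc12` gives 28400 nM

Compound 2 carries the higher number of the two measured compounds, and compound 1 is its nearest neighbour. Compound 3 `Nc1n[nH]c2cc(-c3cn([C@@H]4CN[C@H](C(=O)Nc5ccc(Br)cc5)C4)nn3)ccc12` is not yet measured. Its change is 4-bromophenyl in place of 2,4-dichlorophenyl on an amide-type nitrogen. Going by the values given here, one measured step bears on this place: a 3.4-fold higher number from compound 1 to compound 2 (0.53 log units; beyond the scatter), modest and beyond the scatter, with 2,4-dichlorophenyl as the entering group. Among the compounds with values here, no bromine-bearing compound has been measured, so the direction remains tentative. A modest move toward a lower number in this assay is expected, no larger than that measured step. The expected step runs a 1.8-fold lower number from compound 2 to compound 3 (0.25 log units; within the scatter) on this estimate. For compound 3 the estimated value is 16000 nM with an expected range from 6000 nM to 40000 nM as the likely span.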

Compound 3, half-maximal inhibitory concentration: 10300 nM
Beside the measured number, compound 3's estimate is 1.6-fold (0.19 log units) above it, and the stated range covers the measured number.
By their numbers in this assay, from the lowest: compounds 1 and 3 (each within the scatter of the next); then compound 2.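

In this assay, the amide aryl position gives a second step beyond the scatter, a 2.8-fold lower number from compound 2 to compound 3 (0.44 log units; beyond the scatter), so compound 2 now stands apart from both other amides rather than from compound 1 alone. By contrast, a 1.2-fold higher number from compound 1 to compound 3 (0.09 log units; within the scatter), which lies within the scatter, so 4-bromophenyl and 4-chloro-3-(trifluoromethyl)phenyl cannot be told apart in this read-out despite their different substitution. Nothing measured here accounts for these differences.

The change to compound 3 swaps the halogen and loses a chlorine in one step, and a 4-chlorophenyl group would separate the two. As far as these compounds go, how an amine or a carboxylic acid on the phenyl ring, or a cyclohexyl group in its place, would read at this position remains open.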